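Chloro on the pyridine of a fused diazabicycle

This account rests on a few compounds, and the source may have more. Where it says the series, first, only, none or still open, it means among the compounds named here.

Compound 3 `c1cncc(N2C[C@H]3CCNC[C@H]32)c1` stands second highest of the three numbers in a functional assay on HEK293 cells for agonist activity at Neuronal acetylcholine receptor; alpha3/beta4 (Homo sapiens), read by FLIPR (a lower number here means that less compound is needed, a higher number that more compound is needed for the effect), where compound 3 gives 1540 nM. Its nearest neighbour is compound 2 `c1cncc(N2C[C@@H]3CCNC[C@@H]32)c1`, which gives 1700 nM; the step of a 1.1-fold lower number from compound 2 to compound 3 (0.04 log units; within the scatter) rests on (the fact that compounds 2 and 3 differ only in the configuration as drawn). Furthest away is compound 1 `COc1cc(N2CC[C@H]3CN[C@H]3C2)cnc1Br`, which gives 8 nM and carries a bromo and a methoxy on a different bicyclic core.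

Compound 4 `Clc1ccc(N2C[C@H]3CCNC[C@H]32)cn1` differs from compound 3 by chloro in place of hydrogen on an aromatic carbon. Within the data shown here, no measured pair isolates a halogen on the pyridine, so the single measured step, a stereochemical one, does not bear on this change. Among the measured compounds shown here, the only hint is compound 1, whose halogenated pyridine sits on a far lower number than compound 3, though its core and methoxy also differ.

Compound 4 is therefore expected to show a moderately lower number, the step of a 5.1-fold lower number from compound 3 to compound 4 (0.71 log units; beyond the scatter) being the estimate. For compound 4 the estimated value is 300 nM, with a range from 60 nM to 1500 nM.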

Compound 4, half-maximal effective concentration: 1520 nM
Compound 4: the middle estimate sits 5.1-fold (0.70 log units) below what was measured; the measured number lies above the stated range.
By their numbers in this assay, from the lowest: compound 1; then compounds 4, 3 and 2 (each within the scatter of the next).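

In this assay, chloro in place of hydrogen on an aromatic carbon, next to the ring nitrogen, gives a 1.0-fold lower number from compound 3 to compound 4 (0.01 log units; within the scatter). On the shared core, then, this position reads the same with chloro as with hydrogen, and the chloro alone does not bring the core to a number like that of compound 1, at 8 nM. Nothing known about these compounds bears on why this change leaves no mark.

Compound 1 differs from compound 4 in more than one place, so its low number cannot be assigned to its bromo, its methoxy or its core. Also open, as far as these compounds go, is how this position would read with a fluoro, a methyl or an amine, and whether a methoxy on the shared core would change the number.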